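The compounds below may be only part of what the source reports. "The series", "measured", "known", "first", "only" and "open" are said of these compounds alone.

The compounds measured so far:

Compound 1 `Cn1c(=O)c2c(nc(SCCc3ccc(F)cc3)n2C)n(C)c1=O` gives 71 nM in an assay on microsomes for inhibition of Amine oxidase [flavin-containing] B (Homo sapiens), read by fluorescence and spectrophotometry, with a stated time of 20 min; a lower number here means a stronger inhibitor, a higher number a weaker inhibitor.
Compound 2 `Cc1ccc(CCSc2nc3c(c(=O)n(C)c(=O)n3C)n2C)cc1` gives 72 nM in this assay.
Compound 3 `Cn1c(=O)c2c(nc(SCCc3cccc(Br)c3)n2C)n(C)c1=O` gives 40 nM in this assay.

Compound 3 holds the lowest number of the three, but only by steps within the scatter: a 1.8-fold lower number from compound 1 to compound 3 (0.25 log units; within the scatter) and a 1.8-fold lower number from compound 2 to compound 3 (0.26 log units; within the scatter). The step of a 1.0-fold higher number from compound 1 to compound 2 (0.01 log units; within the scatter) is likewise within the scatter. Compound 4 `Cn1c(=O)c2c(nc(SCCCc3cccc(Cl)c3)n2C)n(C)c1=O` is unmeasured; it differs from compound 3 by 3-chlorobenzyl in place of 3-bromophenyl on a saturated chain carbon, two bonds along the chain from a sulfur. For the measured compounds named here, no measured step alters the chain, so only the aromatic swaps bear on this change, and all were within the scatter. The writer therefore expects no step beyond the scatter, a 1.3-fold higher number from compound 3 to compound 4 (0.10 log units; within the scatter), and estimates compound 4 at 50 nM, between 20 nM and 130 nM.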

Compound 4, half-maximal inhibitory concentration: 62 nM
Beside the measured number, compound 4's estimate is 1.2-fold (0.09 log units) below it, within the range that was stated.
By their numbers in this assay, from the lowest: compounds 3, 4, 1 and 2 (each within the scatter of the next).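

In this assay, compound 4 is the first shown with a change that reaches the chain itself, and 3-chlorobenzyl in place of 3-bromophenyl on a saturated chain carbon stays within the scatter (a 1.6-fold higher number from compound 3 to compound 4 (0.19 log units; within the scatter)). Its steps from the other two compounds are also within the scatter (a 1.2-fold lower number from compound 2 to compound 4 (0.06 log units; within the scatter); a 1.1-fold lower number from compound 1 to compound 4 (0.06 log units; within the scatter)). So, among these compounds, this position tolerates the 3-chlorobenzyl group without a step beyond the scatter.

From the compounds shown here alone, what a 3-bromobenzyl group or an amine would give at this place stays open, so the part played by the chain cannot be told from that of the chlorine. Nothing given here offers an explanation for these steps.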